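Dimethylamino in place of ethoxy on compound 3

A few compounds are considered here, and "the series" means these few. Any claim that something is new, unique, unknown or untested is made for them only; others in the source may bear on it.

Compound 1 `CCOc1ccc(C(=O)NNc2c(Br)cccc2Br)cc1` gives > 100000 nM as a limit of the assay
Compound 2 `CCOc1ccc(C(=O)NNc2c(C)cccc2C)cc1` gives > 100000 nM as a limit of the assay
Compound 3 `CCOc1ccc(C(=O)NNc2c(Br)cc(Br)cc2Br)cc1` gives 54800 nM as a number

Among the measured compounds shown here, in a toxicity assay on MDCK cells (Canis lupus familiaris) for cytotoxicity, read by CCK-8 assay, with a stated time of 48 h (a higher number here means that more compound is tolerated, a lower number that less compound is tolerated), compound 3 at 54800 nM holds the only number. Shown beside it is the limit of > 100000 nM in this assay, at which 2 of the 3 values shown sit, and nothing else. For the measured compounds named here, the one measured step is an at least 1.8-fold lower number from compound 1 to compound 3 (0.26 log units; that floor lies within the scatter) and came with bromo in place of hydrogen on an aromatic carbon. The change to compound 4 `CN(C)c1ccc(C(=O)NNc2c(Br)cc(Br)cc2Br)cc1` is dimethylamino in place of ethoxy on an aromatic carbon and reads dimethylamino in place of ethoxy on an aromatic carbon. Going by the values given here, no measured step touches this group, so compound 3 at 54800 nM serves as the anchor and no shift beyond the scatter is expected in this assay with neither direction favoured. The estimated move is a 1.1-fold lower number from compound 3 to compound 4 (0.04 log units; within the scatter) and stays small. Compound 4 is estimated at 50000 nM with a range from 20000 nM to 100000 nM as expected bounds.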

Compound 4, half-maximal cytotoxic concentration: 20300 nM
Compound 4: middle estimate off by 2.5-fold (0.39 log units), on the high side; the measured number falls inside the stated range.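

In this assay, among the compounds shown here, dimethylamino in place of ethoxy gives a 2.7-fold lower number from compound 3 to compound 4 (0.43 log units; beyond the scatter), the first step beyond the scatter and the first to touch this position, para to a large group. Tolerance therefore responds to the group here, which the earlier compounds could not show. Both groups have the same counts of heavy atoms, donors and acceptors, so those counts do not separate them.

From the compounds shown here alone, whether a primary amine or a longer alkoxy chain here would shift the number further remains open. Also open is whether this step carries over to compound 1 and compound 2, since few values are numbers: the limit of > 100000 nM in this assay, at which 2 of the 4 values shown sit.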